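A few compounds are considered here, and "the series" means these few. Any claim that something is new, unique, unknown or untested is made for them only; others in the source may bear on it.

- Compound 1 `Cc1oc(-c2c(Cl)cccc2Br)nc1CN1CCC(C(=O)NCCCN2C[C@H](C)C[C@H](C)C2)CC1`: > 83 ug/mL
- Compound 2 `Cc1ccccc1-c1nc(CN2CCC(C(=O)NCCN3C[C@H](C)C[C@H](C)C3)CC2)c(C)o1`: > 67 ug/mL
- Compound 3 `Cc1cccc(F)c1-c1nc(CN2CCC(C(=O)NCCCN3C[C@H](C)C[C@H](C)C3)CC2)c(C)o1`: > 72 ug/mL

These results come from a physicochemical assay for solubility, in phosphate buffer, measured as kinetic solubility, at pH 7.4 (on this read-out higher numbers stand for higher solubility and lower numbers for lower solubility), and each one is a limit of the assay, not a true number. Compound 3 stands at > 72 ug/mL, which is likewise only a limit. Compound 4 `COc1cccc(C)c1-c1nc(CN2CCC(C(=O)NCCCN3C[C@H](C)C[C@H](C)C3)CC2)c(C)o1` carries methoxy in place of fluoro on an aromatic carbon. Within the data shown here, the only measured step that bears on this change is a step that the two limits leave unreadable from compound 1 to compound 3, so it offers no size to carry over. The estimated change is a number no higher from compound 3 to compound 4 (the limit leaves the size open), meaning that no step beyond the scatter is expected in this assay, in either direction. For compound 4 the expected value is 72 ug/mL, with an estimated range from 40 ug/mL to 110 ug/mL.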

Compound 4, solubility: > 73 ug/mL
Compound 4 was reported as a limit; the forecaster's own chance of this, stated with the estimate: 85%; middle value at least 1.0-fold (0.00 log units) from the limit.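

In this assay, among these compounds, compound 4 gives > 73 ug/mL, which is a limit of the assay, so no step from compound 1 or compound 3 to compound 4 can be read. The compounds shown leave open whether methoxy in place of fluoro changes the true value at all.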